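A few compounds are considered here, and "the series" means these few. Any claim that something is new, unique, unknown or untested is made for them only; others in the source may bear on it.

The measured compounds:
Compound 1 `O=c1[nH]c(=S)ccn1[C@@H]1O[C@H](COP(=O)(O)O)[C@@H](O)[C@H]1O` gives > 100000 nM in an in vitro functional assay on 1321-N1 cells for agonist activity at P2Y purinoceptor 6 (Homo sapiens), read by scintillation proximity assay and inositol phosphate accumulation (a lower number here means that less compound is needed, a higher number that more compound is needed for the effect), a limit of the assay and not a number.
Compound 2 `CSc1nc(=O)ccn1[C@@H]1O[C@H](COP(=O)(O)OP(=O)(O)O)[C@@H](O)[C@H]1O` gives 4700 nM in this assay.
Compound 3 `CCSc1nc(=O)ccn1[C@@H]1O[C@H](COP(=O)(O)O)[C@@H](O)[C@H]1O` gives > 100000 nM in this assay, again a limit and not a number.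

Compound 3 thus stands at the limit of > 100000 nM in this assay, at which 2 of the 3 values shown sit. Among the measured compounds shown here, of the three measured compounds only compound 2 returns a number in this assay; compound 1 and compound 3 both end at the limit, so no step between measured compounds can be computed.

The compound still to be measured is compound 4 `Nc1nc(=O)ccn1[C@@H]1O[C@H](COP(=O)(O)O)[C@@H](O)[C@H]1O`. It differs from compound 3 in one place: amino in place of ethylsulfanyl on an aromatic carbon. For the measured compounds named here, nothing among the measured compounds isolates this exchange, so the direction and size of the step rest on compound 3 alone. Compound 4 is expected to stay at or close to the limit, with a step of a number no higher from compound 3 to compound 4 (the limit leaves the size open) in this assay. The estimate for compound 4 is 100000 nM, with a range from 20000 nM to 300000 nM, and a limit rather than a number is the more likely outcome.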

Compound 4, half-maximal effective concentration: > 100000 nM
Compound 4 gave a limit, no number; the forecaster's own chance of this, stated with the estimate: 70%; the middle value lies on the limit itself.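

Compound 3 and compound 4 both end at a limit in this assay, so no step can be read between them: the limit of > 100000 nM in this assay, at which 3 of the 4 values shown sit.

The compounds shown leave open whether amino in place of ethylsulfanyl changes the half-maximal effective concentration at all, and in which direction.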